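Methyl addition to the weakest compound of the series

The compounds below may be only part of what the source reports. "The series", "measured", "known", "first", "only" and "open" are said of these compounds alone.

Among the measured compounds shown here, compound 2 `CCOC(=O)c1sc2ccccc2c1Nc1cc(OC)c(OC)c(OC)c1` holds the highest of the three numbers so far at 3100 nM in a functional assay on HeLa cells (Homo sapiens) for cytotoxicity, read by MTT assay, with a stated time of 72 h (a lower number here means a stronger inhibitor, a higher number a weaker inhibitor), and lies far beyond the scatter from both other compounds. Compound 1 `COC(=O)c1sc2cc(OC)ccc2c1Nc1cc(OC)c(OC)c(OC)c1` reads 0.28 nM in this assay and compound 3 `COC(=O)c1sc2nc(C)ccc2c1Nc1cc(OC)c(OC)c(OC)c1` reads 0.18 nM there. These two values are within the scatter of each other.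

Compound 4 `CCOC(=O)c1sc2cccc(C)c2c1Nc1cc(OC)c(OC)c(OC)c1` departs from compound 2 in one place only: methyl in place of hydrogen on an aromatic carbon with methyl in place of hydrogen on an aromatic carbon. That carbon belongs to a six-membered aromatic ring of carbon only, ortho to a fused ring and meta to a fused ring.

For the measured compounds named here, no measured pair isolates this change. Compound 1 and compound 3 each differ from compound 2 in more than one place, so their much lower numbers cannot be assigned to any single group. In this assay the expectation is therefore a small step, leaning toward a lower number and possibly none beyond the scatter, with wide uncertainty in either direction. Going by the values given here, the expected step is a 2.1-fold lower number from compound 2 to compound 4 (0.32 log units; beyond the scatter) and rests on no precedent from the other compounds. Compound 4 is estimated at 1500 nM with an expected range from 150 nM to 10000 nM as its likely span.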

Compound 4, half-maximal inhibitory concentration: 2520 nM
Compound 4: middle estimate off by 1.7-fold (0.23 log units), on the low side; the measured number falls inside the stated range.
By their numbers in this assay, from the lowest: compounds 3 and 1 (each within the scatter of the next); then compounds 4 and 2 (each within the scatter of the next).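

In this assay, among the compounds shown here, methyl in place of hydrogen on an aromatic carbon of the six-membered aromatic ring of carbon only, ortho to a fused ring and meta to a fused ring, gives a 1.2-fold lower number from compound 2 to compound 4 (0.09 log units; within the scatter), the first comparison that isolates a single change. On this evidence, a methyl group at this carbon does not separate compound 4 from compound 2, so this one position, with this small group, tolerates the change without a readable shift in the cell result. Nothing available explains why the result stays flat here.

On these data alone, whether this carbon stays as insensitive with an amine, a hydroxyl group or a longer chain in place of methyl remains open, since a single small substituent says little about the position as a whole. Compound 1 and compound 3 still differ from compound 2 and compound 4 in more than one place, so those steps cannot be read, and a single-place pair would be needed, such as a carboxylic acid in place of the ethyl ester on the core of compound 2.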